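A Dichlorophenyl Swap at the Assay Limit

The source may report more compounds than this note shows. Statements on the series, on what has been measured and on what is new or still open speak of the compounds shown alone.

Compound 1 `COc1cc(-n2ncnc2-c2ccc(Cl)cc2)cc(OC)c1OC` gives > 10000 nM (a limit)
Compound 2 `COc1cc(-c2ncnn2-c2ccc(F)cc2)cc(OC)c1OC` gives > 10000 nM (a limit)

The test used here is a functional assay on MCF7 cells (Homo sapiens) for antiproliferative activity, read by MTT assay, with a stated time of 72 h; a lower number here means a stronger inhibitor, a higher number a weaker inhibitor. In this assay compound 2 gives > 10000 nM, which is a limit of the assay and not a number. Compound 1 stands at that same limit, so the two compounds cannot be ranked against each other. Among the compounds with values here, the record so far therefore holds only (the limit of > 10000 nM in this assay, at which 2 of the 2 values shown sit), and no measured step shows how much a change of group can move the result.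

Compound 3 `COc1cc(-c2ncnn2-c2ccc(Cl)c(Cl)c2)cc(OC)c1OC` keeps the core of compound 2 and changes one group, with 3,4-dichlorophenyl in place of 4-fluorophenyl on an aromatic nitrogen. Within the data shown here, with no measured step as a guide, the expectation in this assay is no change beyond the usual scatter, and no direction is favoured. The expected size of the change is a step that the limit leaves unreadable from compound 2 to compound 3. The estimated value for compound 3 is 12000 nM, with an expected range from 3000 nM to 40000 nM.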

Compound 3, half-maximal inhibitory concentration: > 10000 nM
Compound 3 was reported as a limit (the forecaster's own chance of this, stated with the estimate: 75%); the middle value does not contradict the limit.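

In this assay compound 3 gives > 10000 nM, which is a limit of the assay and not a number. No step from compound 2 to compound 3 can therefore be read, and the record holds only one result: the limit of > 10000 nM in this assay, at which 3 of the 3 values shown sit.

The compounds shown leave open whether changing the group on the aromatic nitrogen moves the result in this assay at all, and by how much.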